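Aryl ketone variation on the hydroxamate series

A few compounds are considered here, and "the series" means these few. Any claim that something is new, unique, unknown or untested is made for them only; others in the source may bear on it.

Measured so far:
- compound 1, `Cc1ccc(C(=O)c2ccc3c(ccn3Cc3ccc(C(=O)NO)cc3)c2)cc1`: 11.9 nM
- compound 2, `COc1cccc(C(=O)c2ccc3c(ccn3Cc3ccc(C(=O)NO)cc3)c2)c1`: 16.4 nM
- compound 3, `COc1cc(C(=O)c2ccc3c(ccn3Cc3ccc(C(=O)NO)cc3)c2)cc(OC)c1OC`: 1540 nM

In an assay on isolated protein for inhibition of protein deacetylase HDAC6 (Homo sapiens) (a higher number here means a weaker inhibitor, a lower number a stronger inhibitor), compound 2 stands second highest of the three numbers. Its nearest neighbour is compound 1, with the step of a 1.4-fold higher number from compound 1 to compound 2 (0.14 log units; within the scatter); its furthest is compound 3, whose value is a far higher number, beyond the scatter.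

The next compound, compound 4, `O=C(NO)c1ccc(Cn2ccc3cc(C(=O)c4ccc(F)cc4)ccc32)cc1`, differs from compound 2 in one place: 4-fluorophenyl in place of 3-methoxyphenyl on a carbonyl carbon. Among the measured compounds shown here, this is a change of the same kind as the one between compound 1 and compound 2, where one single-substituted phenyl on the carbonyl carbon replaced another and the step of a 1.4-fold higher number from compound 1 to compound 2 (0.14 log units; within the scatter) stayed within the scatter. Compound 3, with three methoxy groups, is the only case where this position moved the number far, and compound 4 carries one substituent only. A step within the scatter is therefore expected in this assay, with no preferred direction; the expected step is a 1.3-fold lower number from compound 2 to compound 4 (0.10 log units; within the scatter).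

Compound 4 is estimated at 13 nM, expected to fall between 5 nM and 35 nM.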

Compound 4, half-maximal inhibitory concentration: 9.25 nM
The estimate for compound 4 lay 1.4-fold (0.15 log units) above the measured number; low and high end bracket the measured number.
By their numbers in this assay, from the lowest: compounds 4, 1 and 2 (each within the scatter of the next); then compound 3.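

In this assay, fluoro in place of methyl on an aromatic carbon gives a 1.3-fold lower number from compound 1 to compound 4 (0.11 log units; within the scatter), and 4-fluorophenyl in place of 3-methoxyphenyl on a carbonyl carbon gives a 1.8-fold lower number from compound 2 to compound 4 (0.25 log units; within the scatter). Both steps stay within the scatter, so compound 1, compound 2 and compound 4 form a set of single-substituted phenyl ketones with indistinguishable numbers, a pattern that compound 3, with its three methoxy groups, does not join; the loss of the hydrogen-bond acceptor counted on 3-methoxyphenyl leaves the number within the scatter. No measurement on hand accounts for these small steps.

Still open, from the compounds shown here alone, is how the number responds to an amine or a carboxylic acid on this phenyl ring. Also open, going by these compounds, is whether two methoxy groups already shift the number as far as the three on compound 3.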